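From fluoro to hydroxy on a shared core

The compounds below may be only part of what the source reports. "The series", "measured", "known", "first", "only" and "open" are said of these compounds alone.

Measured so far in a functional assay on HepG2 cells (Homo sapiens) for antiproliferative activity, read by MTT assay, with a stated time of 48 h; on this read-out higher numbers stand for weaker inhibition and lower numbers for stronger inhibition:
compound 1 `CC(=O)N1N=C(c2ccc3ccccc3c2)OC1c1ccccc1` gives 2.11 ug/mL
compound 2 `CC(=O)N1N=C(c2ccc3ccccc3c2)OC1c1ccccc1Cl` gives 4.32 ug/mL
compound 3 `CC(=O)N1N=C(c2ccc3ccccc3c2)OC1c1ccccc1F` gives 3.36 ug/mL

These three compounds share a core and differ only in one group on the same aromatic ring. At 3.36 ug/mL compound 3 has the middle number of the three, but it cannot be told apart from either neighbour. The data show a 1.6-fold higher number from compound 1 to compound 3 (0.20 log units; within the scatter) and also a 1.3-fold lower number from compound 2 to compound 3 (0.11 log units; within the scatter). The next compound, compound 4 `CC(=O)N1N=C(c2ccc3ccccc3c2)OC1c1ccccc1O`, has hydroxy in place of fluoro on an aromatic carbon, ortho to a large group (hydroxy in place of fluoro on an aromatic carbon).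

Among the compounds with values here, no hydroxy compound has been measured yet, so the guide is indirect. Within the data shown here, the nearest evidence is how little this position has moved the number so far. The largest step seen is a 2.0-fold higher number from compound 1 to compound 2 (0.31 log units; beyond the scatter), and it is only modest. Swapping one group for another here, as in a 1.3-fold lower number from compound 2 to compound 3 (0.11 log units; within the scatter), changed nothing measurable. A similar small effect is therefore expected, with no clear direction. The expected step is a 1.1-fold lower number from compound 3 to compound 4 (0.05 log units; within the scatter), and a real shift in this assay is not anticipated. For compound 4 the estimated value is 3 ug/mL, with an expected range from 1.3 ug/mL to 7 ug/mL.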

Compound 4, half-maximal inhibitory concentration: 1.84 ug/mL
Beside the measured number, compound 4's estimate is 1.6-fold (0.21 log units) above it, within the range that was stated.
By their numbers in this assay, from the lowest: compounds 4, 1, 3 and 2 (each within the scatter of the next, the first and the last beyond it).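

In this assay, the hydroxy group brings a hydrogen-bond donor to this position, yet neither comparison with its closest neighbours separates it from them: a 1.1-fold lower number from compound 1 to compound 4 (0.06 log units; within the scatter), and a 1.8-fold lower number from compound 3 to compound 4 (0.26 log units; within the scatter), so swapping in hydroxy for hydrogen or fluoro has no effect that can be told from ordinary assay variation. Within the data shown here, the new information comes from the comparison with the chloro compound, where the data show a 2.3-fold lower number from compound 2 to compound 4 (0.37 log units; beyond the scatter), a modest step but one beyond the scatter, which makes compound 2 the only compound here that stands apart from two others, compound 1 and compound 4, while it still cannot be told apart from compound 3. Nothing available here explains why chloro and hydroxy end up apart on this read-out.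

The compounds shown cover only hydrogen, fluoro, chloro and hydroxy at this place, so it remains open whether an amine, a methoxy group or a carboxylic acid would keep the number in the same narrow band. They also leave open whether a larger group, such as a longer chain ending in hydroxy, would produce a clearer shift than any of these small changes.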